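Swapping an Isobutyl for a Pyrazole on the Amide Nitrogen

The compounds below may be only part of what the source reports. "The series", "measured", "known", "first", "only" and "open" are said of these compounds alone.

Of the compounds shown here, two have been tested in an assay on HEK293 cells for agonist activity at transient receptor potential cation channel subfamily M member 8 (Homo sapiens), read by fluorescence and calcium flux, with a stated time of 15 min; on this read-out lower numbers stand for an effect already at smaller amounts and higher numbers for an effect only at larger amounts of compound. Compound 1 `Cc1ccc(OCC(=O)N(Cc2cccs2)CC(C)C)cc1` gives 900 nM there, the higher of the two numbers. Compound 2 `CCN(Cc1cccs1)C(=O)COc1ccc(OC)cc1` gives 120 nM in this assay, a gap that lies beyond the usual scatter; the two differ at several places, so no single change explains it.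

Compound 3 `Cc1ccc(OCC(=O)N(Cc2cccs2)c2ccn[nH]2)cc1` is the next to be measured. It differs from compound 1 in one place: 1H-pyrazol-5-yl in place of isobutyl on an amide-type nitrogen. For the measured compounds named here, no measured pair in this set shows the effect of such a change, so the expectation rests on compound 1 alone. A group of similar size enters, but an aromatic ring with a hydrogen-bond donor and acceptor replaces a plain chain, so a modest shift is expected, more likely toward a higher number. The step from compound 1 to compound 3 is expected to be a 1.8-fold higher number from compound 1 to compound 3 (0.25 log units; within the scatter). For compound 3 the estimate in this assay is 1600 nM, within a range of 300 nM to 8000 nM.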

Compound 3, half-maximal effective concentration: 0.2 nM
Compound 3: middle estimate off by 8000-fold (3.90 log units), on the high side, outside the stated range (below it).
By their numbers in this assay, from the lowest: compound 3; then compound 2; then compound 1.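

In this assay, the amide-type nitrogen proves to be a very sensitive place in this series: 1H-pyrazol-5-yl in place of isobutyl gives a 4500-fold lower number from compound 1 to compound 3 (3.65 log units; beyond the scatter). Compound 1 and compound 2 differ at several places, so they could not show this; here a single change is isolated, and it alone separates compound 1 from compound 3. Nothing measured here explains why the step is so large, so the feature of the entering group responsible for it remains unknown.

The compounds shown leave open whether the aromatic ring alone is enough or whether the ring's hydrogen-bond donor and acceptor also matter. A phenyl ring or a 1-methylpyrazole group on the same nitrogen would help separate these possibilities.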